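Compound 3: hydroxy added to compound 2

The source may report more compounds than this note shows. Statements on the series, on what has been measured and on what is new or still open speak of the compounds shown alone.

compound 1 `C=C1/C=C/C(C)(C)CC2=C(C)C(=O)[C@]3(C[C@@H](C)C=C3/C=C\1C)O2`: 26000 nM
compound 2 `CC1=C2CC(C)(C)/C=C/C/C(C)=C\C3=C[C@H](C)C[C@]3(O2)C1=O`: 26000 nM

In an ADME assay on HEK293 cells (Homo sapiens) for cytotoxicity, read by CellTiter-Glo, with a stated time of 72 h (a higher number here means that more compound is needed for the effect, a lower number that less compound is needed), compound 1 gives 26000 nM and compound 2 gives 26000 nM, so compound 2 stands level with compound 1 at the digits shown. Compound 3 `CC1=C2CC(C)(C)/C=C/[C@H](O)/C(C)=C\C3=C[C@H](C)C[C@]3(O2)C1=O`, not yet measured, carries hydroxy in place of hydrogen on a saturated ring carbon of compound 2: hydroxy in place of hydrogen on a saturated ring carbon. Within the data shown here, no measured pair contains this change, so the data show nothing directly about its size or direction. Among the measured compounds shown here, the only anchor is compound 2 at 26000 nM. The expected outcome, a 1.2-fold higher number from compound 2 to compound 3 (0.06 log units; within the scatter), is no step beyond the scatter, and no firm direction is expected. The estimate for compound 3 is 30000 nM, with an expected range from 10000 nM to 80000 nM.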

Compound 3, half-maximal effective concentration: 26000 nM
Beside the measured number, compound 3's estimate is 1.2-fold (0.06 log units) above it; the range from low to high includes it.
By their numbers in this assay, from the lowest: compounds 1, 2 and 3 (each within the scatter of the next).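

In this assay the series now has a single step at this position: hydroxy in place of hydrogen on a saturated ring carbon, next to the ring atom that bears a methyl group, gives no change at the digits printed from compound 2 to compound 3 (within the scatter). This saturated ring carbon therefore accepts a hydroxy, with its hydrogen-bond donor and acceptor, and the read-out stays within the scatter. No supporting data offer an explanation for this result. From the compounds shown here alone, it remains open whether a methoxy, an amine or a carboxylic acid on this same carbon would also leave the number in place. Going by these compounds, the opposite configuration at this carbon is also open, as is a hydroxy on other saturated ring carbons of the shared core.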